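Imidazole in place of an amino alcohol on a benzylic carbon

The compounds below may be only part of what the source reports. "The series", "measured", "known", "first", "only" and "open" are said of these compounds alone.

Compound 3 `CCC[C@@H](CCO)Nc1nc(N)nc(C)c1Cc1ccc(CNCCO)cc1OC` shares its core with compound 1 `CCC[C@@H](CCO)Nc1nc(N)nc(C)c1Cc1ccc(CNC2CN(C)C2)cc1OC` and compound 2 `CCC[C@@H](CCO)Nc1nc(N)nc(C)c1Cc1ccc(CNC2CNC2)cc1OC`. In an assay on HEK293 cells for agonist activity at Toll-like receptor 8 (Homo sapiens) (a lower number here means that less compound is needed, a higher number that more compound is needed for the effect), compound 3 reaches only the limit of the assay, > 10000 nM. Compound 1 sits at the same limit, > 10000 nM. Compound 2 also stops at the limit, > 10000 nM. The three steps between these compounds, a step that the two limits leave unreadable from compound 1 to compound 2, a step that the two limits leave unreadable from compound 1 to compound 3 and a step that the two limits leave unreadable from compound 2 to compound 3, cannot be sized; all that is known about them is the limit of > 10000 nM in this assay, at which 3 of the 3 values shown sit. Compound 4 `CCC[C@@H](CCO)Nc1nc(N)nc(C)c1Cc1ccc(Cn2ccnc2)cc1OC` differs from compound 3 in one place: 1H-imidazol-1-yl in place of (2-hydroxyethyl)amino on a saturated chain carbon bound to an aromatic carbon. Going by the values given here, none of the measured steps can be read, so no step with a known size bears on this change. With three compounds all at the limit, compound 4 is expected to remain at or near that limit. The expected step in this assay is a number no higher from compound 3 to compound 4 (the limit leaves the size open). The estimate for compound 4 in this assay is 10000 nM, expected to fall between 2000 nM and 50000 nM.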

Compound 4, half-maximal effective concentration: 4900 nM
Beside the measured number, compound 4's estimate is 2.0-fold (0.31 log units) above it; the range from low to high includes it.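

In this assay, compound 4 is the first compound shown with a readable number rather than a limit, so this saturated chain carbon bound to an aromatic carbon can carry a group that gives a measurable result. The change to 1H-imidazol-1-yl gives an at least 2.0-fold lower number from compound 3 to compound 4 (0.30 log units; that floor lies within the scatter), and the same floor appears in an at least 2.0-fold lower number from compound 2 to compound 4 (0.30 log units; that floor lies within the scatter) and in an at least 2.0-fold lower number from compound 1 to compound 4 (0.30 log units; that floor lies within the scatter). Each of these is only a floor set by a limit, so the true sizes remain unknown, and the steps among the three earlier compounds cannot be read: the limit of > 10000 nM in this assay, at which 3 of the 4 values shown sit.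

The compounds shown leave open whether the readable number goes with the five-membered aromatic ring itself or simply with the absence of the amino side chains. A 1H-pyrazol-1-yl group or a dimethylamino group at the same place would help to separate these two readings.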